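The compounds below may be only part of what the source reports. "The series", "measured", "known", "first", "only" and "open" are said of these compounds alone.

Measured so far in a functional assay on MCF7 cells (Homo sapiens) for cytotoxicity, read by MTT assay, with a stated time of 72 h; a lower number here means a stronger inhibitor, a higher number a weaker inhibitor
- compound 1 `COc1cccc(/C=C2\CCC/C(=C\c3ccccc3Br)C2=O)c1OC` gives 9700 nM
- compound 2 `COc1cccc(/C=C2\CCC/C(=C\c3cccc(OC)c3OC)C2=O)c1` gives 5900 nM
- compound 3 `COc1cccc(/C=C2\CCC/C(=C\c3ccc(Cl)c(Cl)c3)C2=O)c1OC` gives 9000 nM

With 5900 nM for compound 2, this compound lies within the usual scatter of both other compounds, so none of the three stands apart from the rest. Compound 4 `COc1cc(/C=C2\CCC/C(=C\c3cccc(OC)c3OC)C2=O)cc(OC)c1` has not been measured. It keeps compound 2 intact apart from one change, methoxy in place of hydrogen on an aromatic carbon (methoxy in place of hydrogen on an aromatic carbon, meta to a large group and meta to a methoxy group).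

The measured steps bear on this only indirectly. Each of the steps of a 1.6-fold lower number from compound 1 to compound 2 (0.22 log units; within the scatter) and a 1.1-fold lower number from compound 1 to compound 3 (0.03 log units; within the scatter) and a 1.5-fold higher number from compound 2 to compound 3 (0.18 log units; within the scatter) swaps one aromatic group for another, and each stays within the scatter. None of them simply adds a methoxy group to an otherwise unchanged compound. Even so, among these three compounds such swaps have not moved the number beyond the scatter, so no real step is expected in this assay here, in either direction. The estimated step is a 1.1-fold lower number from compound 2 to compound 4 (0.03 log units; within the scatter) and it is expected to be too small to tell from the scatter. For compound 4 the estimated value is 5500 nM with an expected range from 2200 nM to 13000 nM in repeated measurements.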

Compound 4, half-maximal inhibitory concentration: 1700 nM
Beside the measured number, compound 4's estimate is 3.2-fold (0.51 log units) above it, outside the stated range (below it).
By their numbers in this assay, from the lowest: compound 4; then compounds 2, 3 and 1 (each within the scatter of the next).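

Putting methoxy in place of hydrogen on an aromatic carbon, meta to a large group and meta to a methoxy group, gives a 3.5-fold lower number from compound 2 to compound 4 (0.54 log units; beyond the scatter) in this assay and is the only step among the compounds shown that lies beyond the scatter. The earlier steps shown here each swapped one aromatic group for another and all stayed within the scatter, so they gave no sign that this assay would respond to any change on these aromatic groups; this result shows that a single added methoxy group at this carbon, with the rest of compound 2 unchanged, is enough to produce a modest but real drop in the number. No measurement available here explains why this addition lowers the number.

As far as these compounds go, it remains open whether this carbon favours methoxy in particular, or whether a hydroxy group, an amine or a longer chain such as ethoxy in the same place would lower the number as well. From the compounds shown here alone, it is also open whether the same addition would produce a similar step in compound 1 or compound 3, which carry a different aromatic group on the other side of the core.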